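A New Group on the Sulfonamide Nitrogen of Compound 2

The compounds below may be only part of what the source reports. "The series", "measured", "known", "first", "only" and "open" are said of these compounds alone.

- Compound 1 `COc1ccc(C(C)=O)cc1S(=O)(=O)Nc1c(N)nc(SC)[nH]c1=O` gives > 1600000 nM as a limit of the assay
- Compound 2 `COc1ccc(C(=O)/C=C/c2ccccc2)cc1S(N)(=O)=O` gives 7700 nM as a measured number
- Compound 3 `COc1ccc(C(=O)/C=C/c2ccc(C)cc2)cc1S(N)(=O)=O` gives 4300 nM as a measured number

All three results come from an ADME assay on NIH3T3 cells (Mus musculus) for cytotoxicity, read by MTT assay, with a stated time of 48 h (on this read-out higher numbers stand for lower toxicity in this test and lower numbers for higher toxicity in this test), and only two of them are true numbers. Compound 2 has a single numerical neighbour. Within the data shown here, the one measured step, a 1.8-fold lower number from compound 2 to compound 3 (0.25 log units; within the scatter), places a methyl in place of hydrogen on an aromatic carbon, so compound 2 and compound 3 sit together on this scale.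

Compound 4 `COc1ccc(C(=O)/C=C/c2ccccc2)cc1S(=O)(=O)Nc1c(N)nc(SC)[nH]c1=O` is compound 2 with one change (a group of 10 heavy atoms (5 carbon, 3 nitrogen, 1 oxygen, 1 sulfur; one six-membered aromatic ring with 2 hetero atoms) in place of a hydrogen atom, on a sulfonamide nitrogen). The new group, with its six-membered aromatic ring with 2 hetero atoms, replaces a hydrogen atom on a sulfonamide nitrogen. The methyl step took place elsewhere in the molecule and offers only a weak guide to a change of this kind. Among the measured compounds shown here, compound 1 is the only measured compound carrying this group on its sulfonamide nitrogen, and its result is the limit of > 1600000 nM in this assay, at which 1 of the 3 values shown sits, in this assay. For the measured compounds named here, no measured step isolates the group, so the expectation below is loose. Resting on compound 1 and its limit > 1600000 nM alone, a move towards higher numbers is expected for compound 4 in this assay on a scale that remains uncertain. The estimate means a 2.6-fold higher number from compound 2 to compound 4 (0.41 log units; beyond the scatter) as an expected step. Compound 4 is expected to read 20000 nM (expected range 5000 nM to 200000 nM).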

Compound 4, concentration lethal to 50% of the cells: 17000 nM
Compound 4: middle estimate off by 1.2-fold (0.07 log units), on the high side; the measured number falls inside the stated range.
By their numbers in this assay, from the lowest: compounds 3 and 2 (each within the scatter of the next); then compound 4. At a limit, above all of these: compound 1.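

In this assay, the group of 10 heavy atoms on the sulfonamide nitrogen now has a measured effect of its own, as there is a 2.2-fold higher number from compound 2 to compound 4 (0.34 log units; beyond the scatter): a modest move towards lower toxicity in this test. The same group also allows a second comparison, which changes the other end of the molecule and shows an at least 94-fold lower number from compound 1 to compound 4 (1.97 log units; beyond the scatter), a large move towards higher toxicity in this test when 2-phenylethenyl stands in place of methyl on a carbonyl carbon, so the new group alone does not carry a compound to the very high reading of compound 1. The size of that second step has no upper bound, since compound 1 gives a limit of the assay and not a true number: the limit of > 1600000 nM in this assay, at which 1 of the 4 values shown sits.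

Among these compounds, only one group on the sulfonamide nitrogen appears here, so it remains open whether a small one such as methyl or acetyl, or a simple amine-bearing chain, would move the number in the same direction. As far as these compounds go, it also remains open whether the methyl on an aromatic carbon that separates compound 3 from compound 2 would leave the reading unchanged with the new group in place.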